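Trifluoromethyl on the core of compound 2

The source may hold more compounds than are shown below. What is called first, only, known or untested is meant among the compounds shown, and "the series" means these compounds.

Among the compounds with values here, compound 2 `Nc1nc2ccccn2c1-c1ccc(O)cc1` is one of three compounds measured in an assay on isolated protein for inhibition of ubiquitin carboxyl-terminal hydrolase 47 (Homo sapiens); on this read-out lower numbers stand for stronger inhibition and higher numbers for weaker inhibition. In this assay compound 2 gives only a limit, > 100000 nM. Compound 1 `CC(=O)Nc1nc2ccccn2c1-c1ccc(O)cc1` likewise gives only a limit, > 100000 nM. Compound 3 `CN(C)c1nc2ccccn2c1-c1ccc(O)cc1` also gives only a limit, > 100000 nM. All three values sit at the limit of > 100000 nM in this assay, at which 3 of the 3 values shown sit, so the steps a step that the two limits leave unreadable from compound 1 to compound 2, a step that the two limits leave unreadable from compound 1 to compound 3 and a step that the two limits leave unreadable from compound 2 to compound 3 cannot be sized; the exchanges of the nitrogen substituent leave no readable trace in this assay.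

Compound 4 `Nc1nc2ccc(C(F)(F)F)cn2c1-c1ccc(O)cc1` differs from compound 2 by trifluoromethyl in place of hydrogen on an aromatic carbon. Within the data shown here, none of the measured steps concerns the place of this change, and none of them is readable, so nothing points to a gain or a loss beyond the scatter. The expectation therefore follows the measured compounds: compound 4 is expected in this assay at 100000 nM, with a range of 30000 nM to 300000 nM, and most probably again only a limit. The step of a number no higher from compound 2 to compound 4 (the limit leaves the size open) is expected to remain within the scatter.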

Compound 4, half-maximal inhibitory concentration: > 100000 nM
Compound 4: a limit, no number; the forecaster's own chance of this, stated with the estimate: 85%; the middle value lies on the limit itself.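

No size can be read for trifluoromethyl in place of hydrogen between compound 2 and compound 4, as both remain limits in this assay: the limit of > 100000 nM in this assay, at which 4 of the 4 values shown sit. The compounds shown leave open whether any change on the shared core yields a measurable value in this assay.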